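Allyl diaryl-methylidene series: halogen changes on one aryl ring

A few compounds are considered here, and "the series" means these few. Any claim that something is new, unique, unknown or untested is made for them only; others in the source may bear on it.

Measured so far:
- compound 1, `C=CCn1c(=O)/c(=C\c2cccc(Cl)c2)[nH]c(=O)/c1=C\c1ccccc1OC`: 8900 nM
- compound 2, `C=CCn1c(=O)/c(=C\c2cccc(Br)c2)[nH]c(=O)/c1=C\c1ccccc1OC`: 2300 nM
- compound 3, `C=CCn1c(=O)/c(=C\c2ccc(F)c(Br)c2)[nH]c(=O)/c1=C\c1ccccc1OC`: "not active" (no number reported) (no number reported)

For the measured compounds named here, in a functional assay on Huh-7 cells (Homo sapiens) for cytotoxicity, read by CCK-8 assay, with a stated time of 72 h (on this read-out lower numbers stand for stronger inhibition and higher numbers for weaker inhibition), compound 1 gives 8900 nM and compound 2 gives 2300 nM; the only single-point step recorded is a 3.9-fold lower number from compound 1 to compound 2 (0.59 log units; beyond the scatter). Compound 3, which carries a 3-bromo-4-fluorophenyl group at the same position, is recorded in this assay as "not active" (no number reported) with no number attached, so it stands below anything the two measured values can place; it cannot be set against compound 1 or compound 2 by a step.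

Compound 4, `C=CCn1c(=O)/c(=C\c2ccccc2F)[nH]c(=O)/c1=C\c1ccccc1OC`, differs from compound 3 by 2-fluorophenyl in place of 3-bromo-4-fluorophenyl on a double-bonded chain carbon bound to an aromatic carbon. Going by the values given here, no recorded step covers this change: the one step in hand concerns a halogen swap on the same ring but not on the group that leaves or enters here, and it gives only a rough scale of what a halogen change on this ring can do in this assay. With compound 3 reported without a number, and compound 1 and compound 2 sitting in the micromolar range, compound 4 is expected to land in a similar weak region, with a real chance that it too returns no number.

The estimate for compound 4 in this assay is 15000 nM, with a range from 4000 nM to 60000 nM.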

Compound 4, half-maximal inhibitory concentration: 31300 nM
Estimate against measurement, compound 4: 2.1-fold (0.32 log units) below; low and high end bracket the measured number.
By their numbers in this assay, from the lowest: compound 2; then compound 1; then compound 4.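

Against the 3-halophenyl compounds, 2-fluorophenyl in place of 3-bromophenyl gives a 14-fold higher number from compound 2 to compound 4 (1.13 log units; beyond the scatter) in this assay while 2-fluorophenyl in place of 3-chlorophenyl gives a 3.5-fold higher number from compound 1 to compound 4 (0.55 log units; beyond the scatter) on the same read-out, so this position on the double-bonded chain carbon tolerates a change of aryl group with a clear loss, and the size of that loss depends on which group leaves. Steps to or from compound 3 cannot be read, as it carries no number, yet the 2-fluorophenyl group of compound 4 still returns a measured value where the 3-bromo-4-fluorophenyl group of compound 3 does not, so a single fluorine on this ring does not by itself remove the number. Nothing at hand gives a reason for this order among the three measured compounds.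

In compound 4 and its two measured neighbours, the identity of the halogen and its place on the ring change together, so a 3-fluorophenyl or 2-bromophenyl group would be needed to separate the two. Also open, as far as these compounds go, is how this position responds to a group other than a halogen, such as an amine, a nitrile or a carboxylic acid on the same ring.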